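Chloropyrazine on the sulfonamide nitrogen of compound 3

A few compounds are considered here, and "the series" means these few. Any claim that something is new, unique, unknown or untested is made for them only; others in the source may bear on it.

Measured in a functional assay on HCT-116 cells (Homo sapiens) for antiproliferative activity, read by MTT assay, with a stated time of 72 h; a higher number here means a weaker inhibitor of growth, a lower number a stronger inhibitor of growth:
- compound 1 `COc1cc(OC)c(/C=C/S(=O)(=O)Cc2cnc(Cl)cn2)c(OC)c1`: > 10000 nM (a limit)
- compound 2 `COc1ccc(NS(=O)(=O)/C=C/c2c(OC)cc(OC)cc2OC)cc1`: 10 nM
- compound 3 `CCOc1ccc(NS(=O)(=O)/C=C/c2c(OC)cc(OC)cc2OC)cc1`: 350 nM

For the measured compounds named here, compound 3 gives the higher of the two actual numbers in this assay, and the only measured step is a 35-fold higher number from compound 2 to compound 3 (1.54 log units; beyond the scatter). That step is large and beyond the scatter. The remaining value is the limit of > 10000 nM in this assay, at which 1 of the 3 values shown sits.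

Compound 4 `COc1cc(OC)c(/C=C/S(=O)(=O)Nc2cnc(Cl)cn2)c(OC)c1` differs from compound 3 by one change: 5-chloropyrazin-2-yl in place of 4-ethoxyphenyl on a sulfonamide nitrogen. Going by the values given here, no measured step covers this replacement directly. Two observations bear on it. The step of a 35-fold higher number from compound 2 to compound 3 (1.54 log units; beyond the scatter) shows that this assay can respond strongly to a small edit within the group on the sulfonamide nitrogen. Compound 1 also carries 5-chloropyrazin-2-yl, though not on a sulfonamide nitrogen, and its > 10000 nM is a limit.

A large move to a higher number is therefore expected, meaning weaker growth inhibition. The expected change is an 8.6-fold higher number from compound 3 to compound 4 (0.93 log units; beyond the scatter). Compound 4 is estimated at 3000 nM, with an expected range of 400 nM to 10000 nM.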

Compound 4, concentration for 50% growth inhibition: > 10000 nM
Compound 4: no number, only a limit (the forecaster's own chance of this, stated with the estimate: 35%); middle value at least 3.3-fold (0.52 log units) from the limit.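

On a sulfonamide nitrogen, 5-chloropyrazin-2-yl in place of 4-ethoxyphenyl gives an at least 28-fold higher number from compound 3 to compound 4 (1.45 log units; beyond the scatter) in this assay, and in place of 4-methoxyphenyl it gives an at least 1000-fold higher number from compound 2 to compound 4 (3.00 log units; beyond the scatter). Compounds 2 and 3 showed only an edit within the alkoxy chain, whereas these steps show that exchanging the whole ring at this position also moves the number strongly upward. Compound 4 gives > 10000 nM, which is a limit and not a number, and 5-chloropyrazin-2-yl now stands at the limit on a sulfonamide nitrogen as well as in compound 1, where it is not on such a nitrogen: the limit of > 10000 nM in this assay, at which 2 of the 4 values shown sit.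

The step between compound 1 and compound 4 cannot be read: both values are limits. Going by these compounds, whether the chlorine or the pyrazine ring goes with the loss stays open, as does how a pyridine ring or an amine-bearing phenyl would read on the sulfonamide nitrogen.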